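This account rests on a few compounds, and the source may have more. Where it says the series, first, only, none or still open, it means among the compounds named here.

Compound 1 `CCCc1nc2ccccc2c(C(=O)O)c1Oc1ccc(-c2ccccc2-c2nn[nH]n2)cc1`: 0.091 nM
Compound 2 `O=C(O)c1c(Oc2ccc(-c3ccccc3-c3nn[nH]n3)cc2)c(C2CC2)nc2ccc(F)cc12`: 0.61 nM

In a functional assay (aorta) for antagonist activity, with Oryctolagus cuniculus as the target (a lower number here means a stronger inhibitor, a higher number a weaker inhibitor), compound 1 holds the lower of the two numbers, and its gap to compound 2 lies beyond the usual scatter. The two compounds differ in more than one place, so their gap says little about any single change. Compound 3 `CCc1nc2ccccc2c(C(=O)O)c1Oc1ccc(-c2ccccc2-c2nn[nH]n2)cc1` departs from compound 1 by hydrogen in place of methyl on a saturated chain carbon, two bonds along the chain from an aromatic carbon in one place only, hydrogen in place of methyl on a saturated chain carbon, which turns propyl to ethyl. Within the data shown here, no measured pair shows this change alone, so the expectation is tentative. A rise in the number is thought likelier than a fall, because compound 1 at 0.091 nM already sits lowest here. The expected move is a 2.2-fold higher number from compound 1 to compound 3 (0.34 log units; beyond the scatter) toward a weaker inhibitor, modest in size. Compound 3 is estimated at 0.2 nM with a range from 0.07 nM to 0.6 nM in this assay once measured.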

Compound 3, antagonist equilibrium constant: 0.12 nM
For compound 3 the middle estimate is 1.7-fold (0.22 log units) above the measured one; measured number inside the range.
By their numbers in this assay, from the lowest: compounds 1 and 3 (each within the scatter of the next); then compound 2.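

In this assay, the chain on the core can go from propyl to ethyl with a 1.3-fold higher number from compound 1 to compound 3 (0.12 log units; within the scatter) as the result, so the two compounds cannot be told apart. Among these compounds, this is the first single-place change read at this position, and it shows that the loss of one carbon on a saturated chain carbon, two bonds along the chain from an aromatic carbon, leaves the number within the usual scatter. No supporting measurement bears on why the two compounds match.

Going by these compounds, whether that holds for a butyl chain or a lone methyl at this place remains open. So does the outcome of putting a branched chain such as isopropyl, or an amine or hydroxyl on the chain, in place of the ethyl.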